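Cyclohexyl for 2-fluorophenyl in a tetrazole amide series

The compounds below may be only part of what the source reports. "The series", "measured", "known", "first", "only" and "open" are said of these compounds alone.

Measured so far in an ADME assay on Caco-2 cells (Homo sapiens) for permeability, read by LC-MS, in the apical to basolateral direction, with a stated time of 60 min, at pH 6.5; on this read-out lower numbers stand for lower permeability and higher numbers for higher permeability:
- Compound 1, `CC(C)(C)[C@@H](O)C(=O)N1N=CC[C@H]1C(=O)NCc1cc(Cl)ccc1-n1cnnn1`: 15 10^-6 cm/s
- Compound 2, `O=C(NCc1cc(Cl)ccc1-n1cnnn1)[C@@H]1C[C@@H]2C[C@@H]2N1C(=O)[C@H](O)c1ccccc1F`: 16 10^-6 cm/s
- Compound 3, `CC(C)(C)OC[C@@H](O)C(=O)N1C[C@@H]2C[C@@H]2[C@H]1C(=O)NCc1cc(Cl)ccc1-n1cnnn1`: 17 10^-6 cm/s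

The three numbers sit close together. Compound 2 stands in the middle of them: its nearest neighbour is compound 3 and its furthest is compound 1, and both gaps are within the scatter of this assay, so none of the three can be set apart from the others. The side groups on the hydroxyacyl carbon vary widely across these three, yet the read-out hardly moves.

Compound 4, `O=C(NCc1cc(Cl)ccc1-n1cnnn1)[C@@H]1C[C@@H]2C[C@@H]2N1C(=O)[C@H](O)C1CCCCC1`, differs from compound 2 in one place: cyclohexyl in place of 2-fluorophenyl on a saturated chain carbon bound to a carbonyl carbon and an oxygen on a saturated carbon. Among the compounds with values here, no step between measured compounds of this kind is known, so the expectation rests on the narrow spread seen above. The step of a 1.1-fold higher number from compound 2 to compound 4 (0.05 log units; within the scatter) is expected to stay within the scatter, with at most a slight lean toward a higher number. Compound 4 is accordingly expected to give 18 10^-6 cm/s in this assay, with a range from 9 10^-6 cm/s to 36 10^-6 cm/s.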

Compound 4, apparent permeability: 16 10^-6 cm/s
Compound 4: the middle estimate sits 1.1-fold (0.05 log units) above what was measured; the measured number falls inside the stated range.
By their numbers in this assay, from the lowest: compounds 1, 2, 4 and 3 (each within the scatter of the next).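

In this assay, within the data shown here, the change at this position reads as no change at the digits printed from compound 2 to compound 4 (within the scatter), the first step here in which only one group differs. Cyclohexyl, a six-membered non-aromatic ring of carbon only, takes the place of 2-fluorophenyl, a six-membered aromatic ring of carbon only, on the saturated chain carbon bound to a carbonyl carbon and an oxygen on a saturated carbon, and the shared core stays the same, so aromaticity of the ring and the fluorine can go together here without a step beyond the scatter. Nothing measured on hand accounts for this result.

Still open, as far as these compounds go, is whether a ring-free longer chain, or a group carrying an amine or a carboxylic acid, on this carbon would stay within the scatter. Also open, from the compounds shown here alone, is whether the same cyclohexyl for 2-fluorophenyl change gives the same step on the core of compound 1.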